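Two Analogues on a Shared Core and an Untested Third

The compounds below may be only part of what the source reports. "The series", "measured", "known", "first", "only" and "open" are said of these compounds alone.

Measured compounds:
Compound 1 `Nc1ncnc2c1cnn2-c1ccc(C(F)(F)F)cc1`: in a functional assay on MCF7 cells (Homo sapiens) for inhibition, with a stated time of 48 h (on this read-out higher numbers stand for weaker inhibition of growth and lower numbers for stronger inhibition of growth), compound 1 gives "not determined" (no result reported).
Compound 2 `CC(=O)OC[C@H]1O[C@@H](Nc2ncnc3c2cnn3-c2ccc(C(=O)O)cc2)[C@H](OC(C)=O)[C@@H](OC(C)=O)[C@@H]1OC(C)=O`: in this assay compound 2 gives > 150000 nM, which is a limit of the assay and not a number.

Compound 1 therefore has no number in this assay; of the two values shown, one is a limit of > 150000 nM in this assay, at which 1 of the 2 values shown sits, and the other is absent. Compound 3 `COC(=O)CNC(=O)c1ccc(-n2ncc3c(N)ncnc32)cc1` is not yet measured. It differs from compound 1 in one place (((methoxycarbonyl)methyl)carbamoyl in place of trifluoromethyl on an aromatic carbon). Within the data shown here, because compound 1 has no value, no step in this assay can be measured from it, so no direction or size beyond the scatter can be stated for the change. Among the measured compounds shown here, the only anchor is compound 2, whose result is a limit. On that basis compound 3 is expected to give about 100000 nM in this assay, with a range from 20000 nM to 300000 nM, and a real chance that only a limit is reported.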

Compound 3, concentration for 50% growth inhibition: > 150000 nM
Compound 3 was reported as a limit; the forecaster's own chance of this, stated with the estimate: 50%; middle value at least 1.5-fold (0.17 log units) away from the limit.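

In this assay compound 3 gives > 150000 nM, a limit of the assay and not a number. Among these compounds, compound 1 has no number to compare with it, so no step between the two can be read. Going by these compounds, whether replacing trifluoromethyl with ((methoxycarbonyl)methyl)carbamoyl changes growth inhibition remains open.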